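The source may report more compounds than this note shows. Statements on the series, on what has been measured and on what is new or still open speak of the compounds shown alone.

Working notes on the series. Compound 1 `Clc1ccc(CSc2nnc(-c3ccncc3)n2-c2ccccc2)cc1` gives 13300 nM in a functional assay on MCF7 cells (Homo sapiens) for inhibition, read by MTT assay, with a stated time of 48 h; a lower number here means a stronger inhibitor, a higher number a weaker inhibitor; compound 2 `O=[N+]([O-])c1cccc(CSc2nnc(-c3ccncc3)n2-c2ccccc2)c1` gives 18300 nM, a step of a 1.4-fold higher number from compound 1 to compound 2 (0.14 log units; within the scatter). Compound 3 `O=C(CSc1nnc(-c2ccncc2)n1-c1ccccc1)N/N=C/c1ccccc1` gives 23600 nM, the highest of the three numbers, though its gaps to compound 2 and to compound 1 are both within the scatter. Compound 4 `O=C(CSc1nnc(-c2ccncc2)n1-c1ccccc1)N/N=C/c1ccccc1O` differs from compound 3 by hydroxy in place of hydrogen on an aromatic carbon. Among the compounds with values here, no measured step touches the phenyl that becomes 2-hydroxyphenyl; the only single-point step on record, a 1.4-fold higher number from compound 1 to compound 2 (0.14 log units; within the scatter), concerns a different part of the shared core and stayed within the scatter, so no step beyond the scatter is expected here. Compound 4 is therefore estimated at 20000 nM, between 8000 nM and 50000 nM, an expected step of a 1.2-fold lower number from compound 3 to compound 4 (0.07 log units; within the scatter).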

Compound 4, half-maximal inhibitory concentration: 10000 nM
Compound 4: middle estimate off by 2.0-fold (0.30 log units), on the high side; the range from low to high includes it.
By their numbers in this assay, from the lowest: compounds 4, 1, 2 and 3 (each within the scatter of the next, the first and the last beyond it).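

Phenyl to 2-hydroxyphenyl gives a 2.4-fold lower number from compound 3 to compound 4 (0.37 log units; beyond the scatter) in this assay, so this position, on an aromatic carbon ortho to a large group, responds to a single added hydroxy beyond the scatter, which the one earlier step, at a different part of the molecule, did not show. Nothing at hand explains this step.

Open, on these data alone, is whether a methoxy, an amine or a fluorine in place of the hydroxy on this ring would give a step of similar size. Also open, as far as these compounds go, is whether a hydroxy on another carbon of the same ring would do so.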